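The source may hold more compounds than are shown below. What is called first, only, known or untested is meant among the compounds shown, and "the series" means these compounds.

Working notes on the series. Compound 1 `CCCOc1ccccc1-c1ncc(C(=O)OCC)c(=O)[nH]1` and compound 2 `CCOC(=O)c1cnc(-c2ccccc2OCC(C)C)[nH]c1=O` share one core; compound 2 carries methyl in place of hydrogen on a saturated chain carbon bound to two saturated chain carbons. In a functional assay on the whole organism (strain Sprague-Dawley) for inhibition, with Rattus norvegicus as the target, with a stated time of 10 min (on this read-out lower numbers stand for an effect already at smaller amounts and higher numbers for an effect only at larger amounts of compound), compound 1 gives 5 mg/kg. In the same read-out compound 2 gives 3 mg/kg, and the step is a 1.7-fold lower number from compound 1 to compound 2 (0.22 log units; within the scatter). Compound 3 `CCOC(=O)c1cnc(-c2ccccc2SC)[nH]c1=O` differs from compound 1 by methylsulfanyl in place of propoxy on an aromatic carbon. For compound 3 the assay reports only a limit, > 25 mg/kg, which is a limit of the assay and not a number, and it sits at the limit of > 25 mg/kg in this assay, at which 1 of the 3 values shown sits. The steps of an at least 5.0-fold higher number from compound 1 to compound 3 (0.69 log units; beyond the scatter) and an at least 8.3-fold higher number from compound 2 to compound 3 (0.92 log units; beyond the scatter) are both beyond the scatter.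

Compound 4 `CCOC(=O)c1cnc(-c2ccccc2SCC)[nH]c1=O` is not yet measured and carries methyl in place of hydrogen on a saturated chain carbon bound to a sulfur. This is the same kind of change as from compound 1 to compound 2, not the same: there the carbon is bound to two saturated chain carbons, here it is bound to a sulfur. For compound 4 the expected step is a number no higher from compound 3 to compound 4 (the limit leaves the size open), a step within the scatter, which rests on compound 1 and compound 2 giving a 1.7-fold lower number from compound 1 to compound 2 (0.22 log units; within the scatter). Compound 4 is therefore expected near 25 mg/kg, between 10 mg/kg and 60 mg/kg, with a limit rather than a number the likelier outcome because compound 3 already stands at the limit of > 25 mg/kg in this assay, at which 1 of the 3 values shown sits.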

Compound 4, dose for 50% inhibition: > 5 mg/kg
Compound 4: a limit, no number; the forecaster's own chance of this, stated with the estimate: 60%; the middle value lies beyond the limit too.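

In this assay compound 4 gives > 5 mg/kg, which is a limit of the assay and not a number. The steps from compound 3 and from compound 1 to compound 4 cannot be read, so methyl in place of hydrogen on a saturated chain carbon bound to a sulfur has no measured size here, and the data neither confirm nor refute that it carries over from a 1.7-fold lower number from compound 1 to compound 2 (0.22 log units; within the scatter), where the carbon is bound to two saturated chain carbons. Within the data shown here, the one readable new step, an at least 1.6-fold higher number from compound 2 to compound 4 (0.22 log units; that floor lies within the scatter), is a floor for ethylsulfanyl in place of isobutoxy, a different change, and it shows only that compound 4 does not separate from compound 2 beyond the scatter.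

As far as these compounds go, for ethylsulfanyl in place of propoxy the data print only a number no lower from compound 1 to compound 4 (the limit leaves the size open); propylsulfanyl and isobutylsulfanyl, the sulfur counterparts of the chains in compound 1 and compound 2, remain open, and either might show whether a longer chain on sulfur gives a number rather than a limit. From the compounds shown here alone, a carboxylic acid in place of the ethyl ester also remains open.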